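Swapping one halogen for another on the amide aryl group

A few compounds are considered here, and "the series" means these few. Any claim that something is new, unique, unknown or untested is made for them only; others in the source may bear on it.

Measured compounds:
compound 1 `CCC(=O)N(C)c1ccc2[nH]c(-c3n[nH]c4ccccc34)cc2n1` — 15700 nM
compound 2 `CN(C(=O)CCc1ccccc1)c1ccc2[nH]c(-c3n[nH]c4ccccc34)cc2n1` — 18100 nM
compound 3 `CN(C(=O)c1ccc(F)cc1)c1ccc2[nH]c(-c3n[nH]c4ccccc34)cc2n1` — 9650 nM

All three share one core and differ only in the group attached to the amide carbonyl. In a functional assay on A549 cells (Homo sapiens) for antiproliferative activity, read by MTT assay, with a stated time of 72 h (on this read-out lower numbers stand for stronger inhibition and higher numbers for weaker inhibition), compound 3 sits at the low end of the three numbers, yet its separations from the others, a 1.6-fold lower number from compound 1 to compound 3 (0.21 log units; within the scatter) and a 1.9-fold lower number from compound 2 to compound 3 (0.27 log units; within the scatter), both fall within the scatter, so the three cannot be told apart with confidence. The remaining step, a 1.2-fold higher number from compound 1 to compound 2 (0.06 log units; within the scatter), is also within the scatter.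

Compound 4 `CN(C(=O)c1ccc(Cl)cc1)c1ccc2[nH]c(-c3n[nH]c4ccccc34)cc2n1` differs from compound 3 by chloro in place of fluoro on an aromatic carbon. Among the compounds with values here, no measured step exchanges one halogen for another, so the only guidance comes from the two steps that introduce the 4-fluorophenyl group, both of which stayed within the scatter, as did every other step in this small set. The expected step from compound 3 to compound 4 is therefore a 1.1-fold lower number from compound 3 to compound 4 (0.06 log units; within the scatter), nothing beyond the scatter. Compound 4 is estimated to give about 8500 nM in this assay, with a likely range from 4000 nM to 18000 nM.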

Compound 4, half-maximal inhibitory concentration: 2220 nM
Beside the measured number, compound 4's estimate is 3.8-fold (0.58 log units) above it, and the stated range ends above it.
By their numbers in this assay, from the lowest: compound 4; then compounds 3, 1 and 2 (each within the scatter of the next).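

In this assay, within the data shown here, the group para to a large group on this aromatic ring turns out to matter: chloro in place of fluoro gives a 4.3-fold lower number from compound 3 to compound 4 (0.64 log units; beyond the scatter), the first step in this set beyond the scatter, and it exchanges only one heavy atom for another. The 4-chlorophenyl group also separates from the ethyl and phenethyl groups on the carbonyl carbon (a 7.1-fold lower number from compound 1 to compound 4 (0.85 log units; beyond the scatter); an 8.2-fold lower number from compound 2 to compound 4 (0.91 log units; beyond the scatter)), whereas the 4-fluorophenyl group of compound 3 could not be told apart from either. Nothing available here explains why this single exchange has such an effect.

From the compounds shown here alone, whether bromo or iodo at the same place would lower the number further remains open. So does whether a methoxy group, a nitrile or an amine there would match chloro or fall back towards fluoro.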